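Fluorobenzyl on the nitrogen: a cytotoxicity estimate

A few compounds are considered here, and "the series" means these few. Any claim that something is new, unique, unknown or untested is made for them only; others in the source may bear on it.

In an ADME assay on C8166 cells (Homo sapiens) for cytotoxicity, read by MTT assay (on this read-out lower numbers stand for higher toxicity in this test and higher numbers for lower toxicity in this test), compound 1 `Cc1cccc(-n2cc(C(=O)O)c(=O)c3c(O)c(Cc4cccc(Cl)c4F)ccc32)c1` gives 71600 nM. Compound 3 `O=C(O)c1cn(Cc2cccc(F)c2)c2ccc(Cc3cccc(Cl)c3F)c(O)c2c1=O` gives 69000 nM, within the usual scatter of compound 1, so these two share the high end of the three numbers. Among the measured compounds shown here, compound 2 `O=C(O)c1cn(Cc2ccccc2)c2ccc(Cc3cccc(Cl)c3F)c(O)c2c1=O` gives 20300 nM, the only clearly lower value.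

Compound 4 `O=C(O)c1cn(Cc2ccc(F)cc2)c2ccc(Cc3cccc(Cl)c3F)c(O)c2c1=O` has not been measured yet. It carries 4-fluorobenzyl in place of 3-methylphenyl on an aromatic nitrogen.

For the measured compounds named here, three measured steps bear on this change. Benzyl in place of 3-methylphenyl gives a 3.5-fold lower number from compound 1 to compound 2 (0.55 log units; beyond the scatter). 3-Fluorobenzyl in place of 3-methylphenyl gives a 1.0-fold lower number from compound 1 to compound 3 (0.02 log units; within the scatter). Fluoro in place of hydrogen on an aromatic carbon gives a 3.4-fold higher number from compound 2 to compound 3 (0.53 log units; beyond the scatter). Going by the values given here, all of these steps are modest or lie within the scatter, and no measured compound carries the 4-fluorobenzyl group itself. The expectation therefore sits between the results for the benzyl and 3-fluorobenzyl groups, leaning slightly towards a lower number than that of compound 1, with no step beyond the scatter.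

The estimated step is a 1.6-fold lower number from compound 1 to compound 4 (0.20 log units; within the scatter). For compound 4 the estimate is 45000 nM, with an expected range from 18000 nM to 110000 nM.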

Compound 4, half-maximal cytotoxic concentration: 65800 nM
Compound 4: the middle estimate sits 1.5-fold (0.17 log units) below what was measured, and the stated range covers the measured number.
By their numbers in this assay, from the lowest: compound 2; then compounds 4, 3 and 1 (each within the scatter of the next).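

In this assay, moving the fluoro from the 3-fluorobenzyl group to the 4-fluorobenzyl group gives a 1.0-fold lower number from compound 3 to compound 4 (0.02 log units; within the scatter), so among these compounds the fluorine's place on the benzyl ring makes no readable difference. Adding fluoro to the plain benzyl group at this new place gives a 3.2-fold higher number from compound 2 to compound 4 (0.51 log units; beyond the scatter), a second modest rise on top of the one seen with the 3-fluorobenzyl group, while a 1.1-fold lower number from compound 1 to compound 4 (0.04 log units; within the scatter) leaves the 4-fluorobenzyl group level with 3-methylphenyl, so that the plain benzyl group alone stands apart on this nitrogen. Nothing available here accounts for why one added fluorine separates the plain benzyl group from the other groups.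

Still open, going by these compounds, is whether this rise belongs to fluorine itself or would appear with any added group on the benzyl ring, a question that a 4-chlorobenzyl or 4-methylbenzyl group on the same nitrogen could help settle. Also open, on these data alone, is how a 2-fluorobenzyl group, or a longer chain such as 2-phenylethyl between the nitrogen and the ring, would read in this assay.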